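Adding a Third Fluoro Group: Compound 3 to Compound 4

A few compounds are considered here, and "the series" means these few. Any claim that something is new, unique, unknown or untested is made for them only; others in the source may bear on it.

The measured compounds and their values:
compound 1, `O=C1C=C(Nc2ccc(F)cc2)C(=O)c2cnccc21`, gives 72%
compound 2, `O=C1C=C(Nc2cccc(F)c2)C(=O)c2cnccc21`, gives 89%
compound 3, `O=C1C=C(Nc2ccc(F)c(F)c2)C(=O)c2cnccc21`, gives 81%

In a functional assay on the whole organism (aorta) with Rattus norvegicus as the target (on this read-out higher numbers stand for larger maximal responses and lower numbers for smaller maximal responses), compound 3 stands second highest of the three numbers. Its nearest neighbour is compound 2, and the step of a number 8 percentage points lower from compound 2 to compound 3 (within the scatter) lies within the scatter. Furthest away is compound 1, and the step of a number 9 percentage points higher from compound 1 to compound 3 (within the scatter) also lies within the scatter. Both of these steps are the same kind of change as the one now at hand: fluoro in place of hydrogen on an aromatic carbon.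

Compound 4, `O=C1C=C(Nc2ccc(F)c(F)c2F)C(=O)c2cnccc21`, differs from compound 3 by fluoro in place of hydrogen on an aromatic carbon. Since the two measured steps of this kind stayed within the scatter, in this assay no step beyond the scatter is expected here either, in no particular direction.

Compound 4 is therefore expected to give 80% in this assay, with an estimated range from 65% to 95%. That estimate means an expected step of a number 1 percentage points lower from compound 3 to compound 4 (within the scatter), within the scatter.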

Compound 4, largest response reached (Emax), in percent of the reference or control that the assay uses: 87%
For compound 4 the middle estimate is 7 percentage points below the measured one, and the stated range covers the measured number.
By their numbers in this assay, from the lowest: compounds 1, 3, 4 and 2 (each within the scatter of the next, the first and the last beyond it).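

In this assay, within the data shown here, fluoro in place of hydrogen on an aromatic carbon ortho to a large group, a place that carries only hydrogen in the earlier compounds, gives a number 6 percentage points higher from compound 3 to compound 4 (within the scatter). This position therefore tolerates fluoro as a third substituent on the six-membered aromatic ring, and the change stays within the scatter here, as it did in the two earlier steps of this kind. No available measurement bears on the reason for this result.

The compounds shown carry only fluoro on this ring, so it remains open whether a larger or different group at this place, such as a methoxy group, an amine or a carboxylic acid, would shift the maximal response beyond the scatter. From the compounds shown here alone, it also remains open how a single fluoro at this place would behave without the other two fluoro groups.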